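Methyl added to the core of compound 2

The source may hold more compounds than are shown below. What is called first, only, known or untested is meant among the compounds shown, and "the series" means these compounds.

Among the compounds with values here, compound 2 `Cc1ncn2c(O)nncc12` is one of two compounds measured in a functional assay for inhibition, with Homo sapiens as the target; on this read-out higher numbers stand for weaker inhibition and lower numbers for stronger inhibition. In this assay compound 2 gives > 48000 nM, which is a limit of the assay and not a number. Compound 1 `CC(C)c1ncn2c(O)nncc12` is the other measured compound. In this assay compound 1 gives > 48000 nM, again a limit. The step between them, a step that the two limits leave unreadable from compound 1 to compound 2, has no readable size because both values sit at the limit of > 48000 nM in this assay, at which 2 of the 2 values shown sit. Compound 3 `Cc1nc(C)n2c(O)nncc12` differs from compound 2 by methyl in place of hydrogen on an aromatic carbon. Within the data shown here, the only measured step concerns a different change on the shared core, and its size cannot be read, so it gives no direction for this assay in either sense. Compound 3 is therefore expected to stay close to the two measured compounds in this assay, estimated at 60000 nM with a range of 20000 nM to 200000 nM. That estimate means an expected step that the limit leaves unreadable from compound 2 to compound 3, within the scatter.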

Compound 3, half-maximal inhibitory concentration: > 48000 nM
Compound 3: a limit, no number (the forecaster's own chance of this, stated with the estimate: 75%); the middle value does not contradict the limit.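

No new step can be read between compound 2 and compound 3, because both values in this assay are limits and not numbers: the limit of > 48000 nM in this assay, at which 3 of the 3 values shown sit.

The compounds shown leave open whether any change on the shared core gives a readable value in this assay, and how large either step is.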